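Trading a Methoxybenzyl Arm for a Carbamoylmethyl One

A few compounds are considered here, and "the series" means these few. Any claim that something is new, unique, unknown or untested is made for them only; others in the source may bear on it.

Of the compounds shown here, three have been measured in a functional assay with Mus musculus as the target; on this read-out lower numbers stand for an effect already at smaller amounts and higher numbers for an effect only at larger amounts of compound. Compound 1 `COc1ccc(Cn2c(=O)n(C3OC(CO)[C@@H](O)[C@H]3O)c3nc(N)nc(O)c32)cc1` gives 2 uM in this assay, the lowest number of the three. Compound 2 `C=CCn1c(=O)n([C@@H](CO)OC(CO)CO)c2nc(N)nc(O)c21` gives 37 uM, and compound 3 `C=CCn1c(=[Se])n(C2OC(CO)[C@@H](O)[C@H]2O)c2nc(N)nc(O)c21` gives 118 uM; both gaps to compound 1 lie beyond the usual scatter, so compound 1 is the most potent of the set. Within the data shown here, compounds 2 and 3 each differ from compound 1 in more than one place, so no single step between measured compounds can be read off.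

Compound 4 `NC(=O)Cn1c(=O)n(C2OC(CO)[C@@H](O)[C@H]2O)c2nc(N)nc(O)c21` has not yet been measured. It differs from compound 1 in one place: carbamoyl in place of 4-methoxyphenyl on a saturated chain carbon bound to an aromatic nitrogen. The change removes a six-membered aromatic ring of carbon only carrying one hydrogen-bond acceptor and brings in a group with one hydrogen-bond donor and one hydrogen-bond acceptor, on the saturated chain carbon bound to an aromatic nitrogen.

Among the measured compounds shown here, no measured pair shows this change, so the direction of the step can only be weighed against the spread of the three numbers. Because compound 1 already holds the lowest value at 2 uM and every other measured compound lies well above it, a move away from the low end seems more likely than a move further down. The step of a 4.0-fold higher number from compound 1 to compound 4 (0.60 log units; beyond the scatter) is expected to raise the number moderately, beyond the scatter. Compound 4 is accordingly estimated at 8 uM, with a range from 2 uM to 40 uM.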

Compound 4, concentration for half-maximal effect: 117 uM
Compound 4: middle estimate off by 15-fold (1.17 log units), on the low side, outside the stated range (above it).
By their numbers in this assay, from the lowest: compound 1; then compound 2; then compounds 4 and 3 (each within the scatter of the next).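

In this assay, among these compounds, the exchange of 4-methoxybenzyl for carbamoylmethyl gives the first direct reading at this position, a large loss of a 59-fold higher number from compound 1 to compound 4 (1.77 log units; beyond the scatter) on an otherwise unchanged molecule. The position on the saturated chain carbon bound to an aromatic nitrogen is therefore not indifferent to what it carries: taking away 4-methoxyphenyl, with its six-membered aromatic ring of carbon only, and bringing in carbamoyl moves the number well beyond the scatter, which compound 2 and compound 3 could not show, as each differs from compound 1 in more than one place. Nothing at hand explains why this step is so large.

Among the compounds shown here, the single step also changes the ring, the methoxy group and the carbamoyl group at once, so it leaves open which of them governs the number. A plain benzyl group would separate the aromatic ring from its methoxy group, while a longer chain ending in carbamoyl, a carboxylic acid or an amine would show whether the loss follows the removal of the ring or the arrival of the new end group.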